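Shifting the nitro group on the aryl substituent

The source may report more compounds than this note shows. Statements on the series, on what has been measured and on what is new or still open speak of the compounds shown alone.

Compound 1 `COc1cc(N2C(N)=C(C#N)C(c3ccc([N+](=O)[O-])cc3)C3=C2CC(C)(C)CC3=O)cc(OC)c1OC` stands highest of the three measured compounds in a functional assay on Ehrlich cells (Mus musculus) for cytotoxicity, tested at 25 ug/mL (on this read-out lower numbers stand for a weaker effect and higher numbers for a stronger effect at the one concentration tested), where compound 1 gives 50%. Its nearest neighbour is compound 2 `COc1cc(N2C(N)=C(C#N)C(/C=C/c3ccccc3)C3=C2CC(C)(C)CC3=O)cc(OC)c1OC`, which in this assay gives 30%; the step of a number 20 percentage points lower from compound 1 to compound 2 (beyond the scatter) accompanies 2-phenylethenyl in place of 4-nitrophenyl on a saturated ring carbon. Compound 3 `COc1cc(N2C(N)=C(C#N)C(c3ccc(OC)c4ccccc34)C3=C2CC(C)(C)CC3=O)cc(OC)c1OC` gives 30%, and the step of a number 20 percentage points lower from compound 1 to compound 3 (beyond the scatter) accompanies 4-methoxynaphthalen-1-yl in place of 4-nitrophenyl on a saturated ring carbon. Between the two weaker compounds there is no change at the digits printed from compound 2 to compound 3 (within the scatter).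

Compound 4 `COc1cc(N2C(N)=C(C#N)C(c3cccc([N+](=O)[O-])c3)C3=C2CC(C)(C)CC3=O)cc(OC)c1OC` has not yet been measured in this assay. It differs from compound 1 by 3-nitrophenyl in place of 4-nitrophenyl on a saturated ring carbon. Both measured steps away from compound 1 exchanged the 4-nitrophenyl for a group of different make-up, and each was a modest fall beyond the scatter. Among the measured compounds shown here, the change to compound 4 keeps the same atoms and only rearranges them, a smaller alteration than either measured one, and no measured step bears directly on it. One therefore expects for compound 4 a step of a number 10 percentage points lower from compound 1 to compound 4 (within the scatter), a small fall or none beyond the scatter, and estimates compound 4 in this assay at 40%, with a range from 20% to 60%.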

Compound 4, a percentage reported as activity, at one concentration (the size of the read-out at that concentration, not a potency): 20%
Compound 4: the middle estimate sits 20 percentage points above what was measured; low and high end bracket the measured number.
By their numbers in this assay, from the lowest: compounds 4, 2 and 3 (each within the scatter of the next); then compound 1.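

In this assay, the step of a number 30 percentage points lower from compound 1 to compound 4 (beyond the scatter) shows that the placement of the nitro group counts at this saturated ring carbon: 3-nitrophenyl and 4-nitrophenyl have the same atoms and the same counts, yet the step is of the same modest class as the exchanges for wholly different groups. Compound 4 also shows no separation from those two exchanged compounds, with a number 10 percentage points lower from compound 3 to compound 4 (within the scatter) and a number 10 percentage points lower from compound 2 to compound 4 (within the scatter) as the printed steps, so among these four compounds the higher number goes with 4-nitrophenyl alone and not with a nitrophenyl group as such. Nothing available here accounts for the difference between the two nitrophenyl groups.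

From the compounds shown here alone, what stays open is whether the higher number of compound 1 needs the nitro group itself or would also appear with another group in its place on the phenyl ring, such as a nitrile, a chlorine atom or an amine. The 2-nitrophenyl group is also unaccounted for here, and a reading at one concentration cannot say whether these differences would hold across a range of concentrations.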